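The source may report more compounds than this note shows. Statements on the series, on what has been measured and on what is new or still open speak of the compounds shown alone.

Compound 1 `CCCCCCCCCCCC[C@@H](O)[C@H]1CC[C@H]([C@H](O)CCCCCCCCCCNC(=O)c2cccs2)O1` and compound 2 `CCCCCCCCCCCC[C@@H](O)[C@H]1CC[C@H]([C@H](O)CCCCCCCCCCNC(=O)c2ccco2)O1` share a core and differ only in the group on a carbonyl carbon. In a functional assay on SNB-78 cells (Homo sapiens) for inhibition, read by colorimetric assay and sulforhodamine B assay, with a stated time of 48 h (on this read-out lower numbers stand for stronger inhibition of growth and higher numbers for weaker inhibition of growth), compound 1 gives 2290 nM and compound 2 gives 100000 nM. Compound 2 therefore has the higher of the two numbers, which means the weaker inhibition of growth.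

Within the data shown here, the only measured step, a 44-fold higher number from compound 1 to compound 2 (1.64 log units; beyond the scatter), came with furan-2-yl in place of thiophen-2-yl. It is large and lies beyond the usual scatter. Compound 3 `CCCCCCCCCCCC[C@@H](O)[C@H]1CC[C@H]([C@H](O)CCCCCCCCCCNC(=O)c2ccoc2)O1` differs from compound 2 in one place: furan-3-yl in place of furan-2-yl on a carbonyl carbon. Here the ring stays a furan, and only its point of attachment changes, whereas the measured step replaced one kind of ring with another. Among the measured compounds shown here, no measurement yet shows what this shift does on its own.

Set against a 44-fold higher number from compound 1 to compound 2 (1.64 log units; beyond the scatter), a smaller step is expected in this assay. With compound 2 at 100000 nM, the expected direction is towards a lower number, although no change beyond the scatter remains possible. The estimated change is a 3.3-fold lower number from compound 2 to compound 3 (0.52 log units; beyond the scatter). For compound 3, the expected value is 30000 nM, within an estimated range of 4000 nM to 100000 nM.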

Compound 3, concentration for 50% growth inhibition: 100000 nM
The estimate for compound 3 lay 3.3-fold (0.52 log units) below the measured number; low and high end bracket the measured number.
By their numbers in this assay, from the lowest: compound 1; then compounds 2 and 3 (each within the scatter of the next).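

In this assay, shifting the attachment point of the furan ring gives no change at the digits printed from compound 2 to compound 3 (within the scatter) and so leaves the read-out unmoved, which means that furan-2-yl and furan-3-yl cannot be told apart at this position. Replacing thiophen-2-yl with furan-3-yl gives a 44-fold higher number from compound 1 to compound 3 (1.64 log units; beyond the scatter) on the same carbonyl carbon, matching in size the step seen earlier with furan-2-yl, so among these three compounds the large gap separates the thiophene from both furans, whichever furan attachment point is used. No measured information accounts for the gap between the thiophene and the furans.

On these data alone, it remains open whether the attachment point matters for a thiophene, which thiophen-3-yl on the same carbonyl carbon would test directly. As far as these compounds go, it is also open how a phenyl ring or a pyrrole ring at this position would compare with compound 1 at 2290 nM and so whether the stronger growth inhibition belongs to the thiophene alone.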